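Bromo-to-methoxy swaps on two different rings

The source may report more compounds than this note shows. Statements on the series, on what has been measured and on what is new or still open speak of the compounds shown alone.

Compound 1 `COc1cc(OC)c(/C=C/S(=O)(=O)Cc2ccc(OC)c(N)c2)c(OC)c1` is the reference point of the series: in a functional assay on DU-145 cells (Homo sapiens) for cytotoxicity, read by trypan blue exclusion, with a stated time of 96 h (on this read-out higher numbers stand for weaker inhibition and lower numbers for stronger inhibition), compound 1 gives 4 nM. Compound 2 `COc1cc(OC)c(/C=C/S(=O)(=O)Cc2ccc(Br)c(N)c2)c(OC)c1` carries bromo where compound 1 carries methoxy; in this assay compound 2 gives 750 nM, and the change methoxy in place of bromo on an aromatic carbon makes the step of a 190-fold lower number from compound 2 to compound 1 (2.27 log units; beyond the scatter). Compound 3 `COc1cc(OC)c(/C=C/S(=O)(=O)Cc2ccc(OC)c(NC(C(=O)O)c3ccc(Br)cc3)c2)c(OC)c1` keeps the methoxy of compound 1 but carries (4-bromophenyl)(carboxy)methyl in place of hydrogen on a nitrogen on an aromatic ring; in this assay compound 3 gives 300 nM, the step being a 75-fold higher number from compound 1 to compound 3 (1.88 log units; beyond the scatter). The difference between the cores of compound 2 and compound 3 is not broken down here; their values simply show compound 3 with the lower number.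

Compound 4 `COc1ccc(C(Nc2cc(CS(=O)(=O)/C=C/c3c(OC)cc(OC)cc3OC)ccc2OC)C(=O)O)cc1` is not yet measured. It differs from compound 3 by methoxy in place of bromo on an aromatic carbon. This is the same kind of change as that from compound 2 to compound 1, not the same: in compound 2 the place is also ortho to an amino group (1 heavy atom), whereas in compound 3 it is only para to a large group on the pendant 4-bromophenyl. Going by the values given here, the earlier step of a 190-fold lower number from compound 2 to compound 1 (2.27 log units; beyond the scatter) was large, but it sat on the shared core; for the pendant ring no measured pair exists, so a smaller step is expected. For compound 4 in this assay the expected value is 150 nM, between 40 nM and 600 nM, an estimated step of a 2.0-fold lower number from compound 3 to compound 4 (0.30 log units; within the scatter).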

Compound 4, half-maximal inhibitory concentration: 100 nM
Compound 4: the middle estimate sits 1.5-fold (0.18 log units) above what was measured, and the stated range covers the measured number.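

In this assay, methoxy in place of bromo moves the number the same way on the pendant ring as on the shared core, with a 3.0-fold lower number from compound 3 to compound 4 (0.48 log units; beyond the scatter), but the size of the step does not carry over from one to the other: the same change on two cores in this assay, a 190-fold lower number (2.27 log units; beyond the scatter) from compound 2 to compound 1 and a 3.0-fold lower number (0.48 log units; beyond the scatter) from compound 3 to compound 4, 63-fold (1.80 log units) apart, beyond the scatter of two such steps. The two pairs show only that the direction agrees in these two cases; the change sits at a different place in each pair, so they cannot separate the role of the core from that of the place. With methoxy on the pendant ring, the substituted nitrogen still leaves a 25-fold higher number from compound 1 to compound 4 (1.40 log units; beyond the scatter), so this swap does not restore the number of compound 1.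

The compounds shown leave open how the number moves when the carboxylic acid of compound 4 gives way to a methyl ester or a primary amide. Also open, going by these compounds, is whether a chloro or an unsubstituted phenyl on the pendant ring would fit with the bromo and methoxy values.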